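Cyclopropyl for Bromo on a Weak Sulfonamide

A few compounds are considered here, and "the series" means these few. Any claim that something is new, unique, unknown or untested is made for them only; others in the source may bear on it.

Compound 1 `NS(=O)(=O)c1ccc(CNc2nc(Nc3cccc(NC(=O)N4CCCC4)c3)ncc2Br)cc1` was tested in an assay on HEK293 cells for displacement of a labelled ligand from MAP/microtubule affinity-regulating kinase 4 (Homo sapiens), read by NanoBRET (on this read-out higher numbers stand for weaker inhibition and lower numbers for stronger inhibition), where compound 1 gives > 10000 nM. That value is a limit of the assay and not a number, as recorded in the limit of > 10000 nM in this assay, at which 1 of the 2 values shown sits. Compound 1 therefore stands at the weak end of what has been measured. Compound 2 `O=C(NCCCNc1nc(Nc2cccc(NC(=O)N3CCCC3)c2)ncc1Br)C1CCC1` gives 72 nM in this assay. The step of an at least 130-fold lower number from compound 1 to compound 2 (2.14 log units; beyond the scatter) is large, but it alters a different part of the molecule, the group on the saturated chain carbon bound to a nitrogen on an aromatic ring. Compound 3 `NS(=O)(=O)c1ccc(CNc2nc(Nc3cccc(NC(=O)N4CCCC4)c3)ncc2C2CC2)cc1` keeps that part of compound 1 and changes only (cyclopropyl in place of bromo on an aromatic carbon). Among the compounds with values here, no measured step touches that position, so the change cannot be sized from the data. The expected step is a number no higher from compound 1 to compound 3 (the limit leaves the size open), with no clear direction. Compound 3 is estimated at 10000 nM, within 3000 nM to 30000 nM, and a limit may again be all that is reported.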

Compound 3, half-maximal inhibitory concentration: > 10000 nM
Compound 3: only a limit was reported (the forecaster's own chance of this, stated with the estimate: 60%); the middle value sits exactly at the limit.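

Compound 1 and compound 3 both rest at a limit of the assay and not at a number, so no step between them can be read: the limit of > 10000 nM in this assay, at which 2 of the 3 values shown sit.

The compounds shown leave open whether cyclopropyl in place of bromo changes the read-out at all, either here or with the side chain of compound 2.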